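The source may hold more compounds than are shown below. What is called first, only, known or untested is meant among the compounds shown, and "the series" means these compounds.

Working notes on the series. Going by the values given here, the shared core of compound 3 `COc1cc2c(Nc3ccc(B(O)O)cc3)ncnc2c(OC)c1OC` carries an aryl group on the amine nitrogen, and within this set only that aryl group is varied. In a functional assay on SGC-7901 cells (Homo sapiens) for antiproliferative activity, read by MTT assay, with a stated time of 72 h (a higher number here means a weaker inhibitor, a lower number a stronger inhibitor), compound 3 gives 434 nM. Compound 1 `COc1cc2c(Nc3cc(F)ccc3Br)ncnc2c(OC)c1OC` gives 18400 nM in this assay. Compound 2 `COc1cc2c(Nc3ccc(Br)c(F)c3)ncnc2c(OC)c1OC` returns only a limit in this assay, namely > 30000 nM. Among the compounds with values here, the single measured step, an at least 1.6-fold higher number from compound 1 to compound 2 (0.21 log units; that floor lies within the scatter), rearranges the halogens on the aryl ring and runs into (the limit of > 30000 nM in this assay, at which 1 of the 3 values shown sits), so its true size is not fixed. Compound 3 stands at the lowest of the two numbers shown, and the gap up to compound 1 lies beyond the usual scatter.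

Compound 4 `COc1cc2c(Nc3ccc(C(F)(F)F)cc3)ncnc2c(OC)c1OC` has not yet been measured. It differs from compound 3 by a group of 4 heavy atoms (1 carbon, 3 fluorine; no ring) in place of a group of 3 heavy atoms (1 boron, 2 oxygen; no ring), on an aromatic carbon. Within the data shown here, no measured step touches this position: the only step, between compound 1 and compound 2, concerns the halogen pattern and gives no guide to the size expected here. The group that enters carries no hydrogen-bond donors or acceptors where the group that leaves carried two of each, and with the boron removed the number is expected to move upward, with a 6.9-fold higher number from compound 3 to compound 4 (0.84 log units; beyond the scatter) estimated to exceed the scatter. Compound 4 is estimated at 3000 nM, with a range of 800 nM to 15000 nM.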

Compound 4, half-maximal inhibitory concentration: > 30000 nM
Compound 4: no number, only a limit (the forecaster's own chance of this, stated with the estimate: 10%); at least 10-fold (1.00 log units) between middle value and limit.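

The aromatic carbon para to a large group now has a measured step: in this assay, trifluoromethyl in place of the boron-bearing group gives an at least 69-fold higher number from compound 3 to compound 4 (1.83 log units; beyond the scatter). On these data alone, compound 4 returns only a limit, and the step is therefore a floor whose true size stays open: the limit of > 30000 nM in this assay, at which 2 of the 4 values shown sit. The earlier step, which rearranged the halogens, had a floor within the scatter, whereas this one lies beyond it, so a single change at this position is enough to separate two compounds clearly in this series.

The compounds shown leave open whether boron itself matters or whether another group at this position, such as a carboxylic acid, an amine or a hydroxyl group, would keep the number close to that of compound 3 at 434 nM. With only trifluoromethyl and the boron-bearing group compared here, and one of the two sitting at a limit, no trend across groups at this position can be stated beyond this one pair.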